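The source may report more compounds than this note shows. Statements on the series, on what has been measured and on what is new or still open speak of the compounds shown alone.

Measured compounds:
Compound 1 `COc1cccc(/C=N/N=C2\C[C@@H](c3ccc(O)cc3)Oc3cc(OC)cc(O)c32)c1` — in a functional assay on L5178Y cells (Mus musculus) for inhibition, read by MTT assay, with a stated time of 24 h (a higher number here means a weaker inhibitor, a lower number a stronger inhibitor), compound 1 gives >= 11300 nM, which is a limit of the assay rather than a number.
Compound 2 `O=C(N/N=C1\C[C@@H](c2ccc(O)cc2)Oc2cc(O)cc(O)c21)OCc1ccccc1` — in this assay compound 2 gives >= 11300 nM, again a limit of the assay rather than a number.

Among the measured compounds shown here, compound 1 therefore has no measured number to stand on: both values shown are limits, and the limit of >= 11300 nM in this assay, at which 2 of the 2 values shown sit, tells that every value so far sits at that same limit. Nothing separates compound 1 from compound 2 in this assay.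

Compound 3 `COc1cc(O)c2c(c1)O[C@H](c1ccc(O)cc1)C/C2=N\NC(=O)c1ccco1` has not yet been measured. It differs from compound 1 by a group of 8 heavy atoms (5 carbon, 1 nitrogen, 2 oxygen; one five-membered aromatic ring with 1 hetero atom) in place of a group of 10 heavy atoms (8 carbon, 1 nitrogen, 1 oxygen; one six-membered aromatic ring of carbon only), on a double-bonded nitrogen. The group that enters, ((furan-2-yl)carbonyl)amino, brings one hydrogen-bond donor where the leaving group had none.

For the measured compounds named here, since no step between measured compounds is given, the size of the change cannot be taken from a precedent. With both measured compounds resting at the limit, compound 3 is expected to remain there as well, so the step that the limit leaves unreadable from compound 1 to compound 3 is expected to be no more than the scatter, if a number appears at all. For compound 3 the estimate is 15000 nM, within 5000 nM to 50000 nM.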

Compound 3, half-maximal inhibitory concentration: >= 11300 nM
Compound 3 gave a limit, no number; the forecaster's own chance of this, stated with the estimate: 80%; the middle value lies beyond the limit too.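

In this assay compound 3 gives >= 11300 nM, which is a limit of the assay and not a number. No step can be read between compound 1 and compound 3, because both values are limits: the limit of >= 11300 nM in this assay, at which 3 of the 3 values shown sit.

The compounds shown leave open how strongly any of them inhibits in this assay, and whether the group on the double-bonded nitrogen matters at all.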